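The source may hold more compounds than are shown below. What is called first, only, known or untested is meant among the compounds shown, and "the series" means these compounds.

The series rests on a shared core, seen in compound 1 `CCOC(=O)c1oc2ccc(NS(=O)(=O)c3ccc(F)cc3)cc2c1C`. In a functional assay on HCT-116 cells (Homo sapiens) for inhibition, read by MTT assay, with a stated time of 72 h (a higher number here means a weaker inhibitor, a lower number a stronger inhibitor), compound 1 gives 10500 nM. Compound 2 `CCOC(=O)c1oc2ccc(N(Cc3ccccc3)S(=O)(=O)c3ccc(C)cc3)cc2c1C` carries a benzyl group on the sulfonamide nitrogen and a 4-methylphenyl group on the sulfonyl. In this assay compound 2 reaches only a limit of the assay, > 40000 nM, so no number is known for it. This is where compound 2 stands: at the limit of > 40000 nM in this assay, at which 1 of the 2 values shown sits. Compound 3 `CCOC(=O)c1oc2ccc(N(Cc3ccccc3)S(=O)(=O)c3ccccc3)cc2c1C` is the next member. Its difference from compound 2 is hydrogen in place of methyl on an aromatic carbon, para to a large group. Among the compounds with values here, no step between two measured compounds is available, so no measured size can be given for this change. Since compound 2 is known only as a limit, the step to compound 3 can be read as no more than an expectation. A change of this kind is expected to move the reading by little, likely not beyond the scatter, with a fair chance that compound 3 also sits at a limit. The change is expected to amount to a step that the limit leaves unreadable from compound 2 to compound 3. Compound 3 is therefore estimated at 45000 nM, within a range from 15000 nM to 150000 nM.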

Compound 3, half-maximal inhibitory concentration: > 40000 nM
Compound 3 ended at the assay's limit; the forecaster's own chance of this, stated with the estimate: 70%; the middle value does not contradict the limit.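

Compound 2 and compound 3 both stand at a limit of this assay, neither gives a number, and no step between them can be read: the limit of > 40000 nM in this assay, at which 2 of the 3 values shown sit.

The compounds shown leave open whether hydrogen in place of methyl on this aromatic carbon changes the reading at all, and by how much.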